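A few compounds are considered here, and "the series" means these few. Any claim that something is new, unique, unknown or untested is made for them only; others in the source may bear on it.

Compound 1, `C=C1[C@H](OC(C)=O)[C@@H](OC(C)=O)[C@@H](OC(C)=O)C(C)(C)/C=C/[C@H](C)[C@H](OC(=O)c2ccccc2)[C@@]2(O)C[C@@](C)(O)[C@H](OC(C)=O)[C@@H]2[C@H]1OCC(C)C`: in a functional assay on NCI/ADR-RES cells (Homo sapiens) for antiproliferative activity, read by MTT assay, with a stated time of 48 h (a higher number here means a weaker inhibitor, a lower number a stronger inhibitor), compound 1 gives > 100000 nM, which is a limit of the assay and not a number.
Compound 2, `C=C1[C@H](OC(C)=O)[C@@H](OC(C)=O)[C@@H](OC(C)=O)C(C)(C)/C=C/[C@H](C)[C@H](OC(=O)c2ccccc2)[C@@]2(O)C[C@@](C)(OC(C)=O)[C@H](OC(C)=O)[C@@H]2[C@H]1OCC(C)C`: in this assay compound 2 gives > 100000 nM, again only a limit.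

Compound 2 therefore has no fixed position on the scale; what is known is the limit of > 100000 nM in this assay, at which 2 of the 2 values shown sit, so that the step that the two limits leave unreadable from compound 1 to compound 2 cannot be read in either direction. The next step takes compound 2 to compound 3, `C=C1[C@H](OC(C)=O)[C@@H](OC(C)=O)[C@@H](OC(C)=O)C(C)(C)/C=C/[C@H](C)[C@H](OC(=O)c2ccccc2)[C@@]2(O)C[C@@](C)(OC(=O)c3ccncc3)[C@H](OC(C)=O)[C@@H]2[C@H]1OCC(C)C`. The change is pyridin-4-yl in place of methyl on a carbonyl carbon. Among the compounds with values here, no measured step bears on this change with a readable size, and the one measured step is itself unreadable. The expectation for the step of a number no higher from compound 2 to compound 3 (the limit leaves the size open) is therefore that it stays within scatter of the limit, with a wide range around it. For compound 3 in this assay the estimate is 100000 nM, with a range from 20000 nM to 300000 nM, and a report of a bare limit again is expected as the most likely outcome.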

Compound 3, half-maximal inhibitory concentration: > 100000 nM
Compound 3 ended at the assay's limit; the forecaster's own chance of this, stated with the estimate: 70%; the middle value sits exactly at the limit.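

In this assay compound 3 gives > 100000 nM, a limit and not a number. Within the data shown here, no step among compound 1, compound 2 and compound 3 can be read. The compounds shown leave open whether any of these changes alters activity at all: the limit of > 100000 nM in this assay, at which 3 of the 3 values shown sit.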